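Methoxy for chloro on the benzyl ring of compound 1

The compounds below may be only part of what the source reports. "The series", "measured", "known", "first", "only" and "open" are said of these compounds alone.

Measured compounds:
compound 1, `CC(C)(C)OC(=O)N1CCN(C(=S)SCc2cn(Cc3ccc(Cl)cc3)nn2)CC1`: 9790 nM
compound 2, `COc1cc(Cn2cc(CSC(=S)N3CCNCC3)nn2)cc(OC)c1OC`: "not determined" (no result reported)
compound 3, `O=C(OCc1ccccc1)N1CCN(C(=S)SCc2cn(Cc3ccc(Cl)c(Cl)c3)nn2)CC1`: 7140 nM

The study covers three measured compounds built on a shared core and tested in a functional assay on MGC-803 cells (Homo sapiens) for inhibition, read by MTT assay, with a stated time of 72 h; a lower number here means a stronger inhibitor, a higher number a weaker inhibitor. Compound 1 gives 9790 nM. Compound 3 gives 7140 nM. These two numbers lie within the usual scatter of each other, so compound 1 cannot be set apart from compound 3 on the numbers shown. For compound 2 no result was reported, and it is simply recorded as "not determined" (no result reported). For the measured compounds named here, no pair of measured compounds differs in only one place, so no single measured step is available as a guide.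

Compound 4, `COc1ccc(Cn2cc(CSC(=S)N3CCN(C(=O)OC(C)(C)C)CC3)nn2)cc1`, differs from compound 1 in one place: methoxy in place of chloro on an aromatic carbon. Going by the values given here, since the two available numbers sit close together and no measured step involves this change, the expected step in this assay is small, with no clear direction beyond the scatter. Compound 4 is therefore estimated at 12000 nM, with a range from 5000 nM to 30000 nM. This estimate corresponds to the step of a 1.2-fold higher number from compound 1 to compound 4 (0.09 log units; within the scatter), expected to stay within the scatter.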

Compound 4, half-maximal inhibitory concentration: 22800 nM
The estimate for compound 4 lay 1.9-fold (0.28 log units) below the measured number; low and high end bracket the measured number.
By their numbers in this assay, from the lowest: compounds 3 and 1 (each within the scatter of the next); then compound 4.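

For the compounds shown here, with everything else in the core of compound 1 held fixed, the exchange of 4-chlorobenzyl for 4-methoxybenzyl gives the first single-place comparison in this assay, and it reads as a 2.3-fold higher number from compound 1 to compound 4 (0.37 log units; beyond the scatter), a modest step that lies beyond the scatter. The position para to the large group is therefore not indifferent to what it carries: here chloro, with no hydrogen-bond acceptor, leaves, methoxy, with 1 hydrogen-bond acceptor, enters, and the result is a weaker inhibitor in this one pair. Nothing measured here accounts for the step, so the pair describes the change without offering any explanation of it.

Going by these compounds, one exchange at one place cannot show whether the weakening belongs to methoxy in particular or would follow any replacement of chloro, so the reading of a fluoro, an amine or a longer ethoxy chain at this position remains open. On these data alone, it also remains open whether the same exchange would give a step of similar size and direction on the core of compound 3, which carries a different group on the far nitrogen and a second chloro on the benzyl ring.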